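This account rests on a few compounds, and the source may have more. Where it says the series, first, only, none or still open, it means among the compounds named here.

In a functional assay, with a stated time of 20 min, tested at 2 uM (a lower number here means a weaker effect, a higher number a stronger effect of the compound at the concentration tested), compound 1 `COc1cc(/C=C/C(=O)C2=C(/C=C/c3ccc(O)c(OC)c3)NC(=O)NC2c2ccccc2O)ccc1O` gives 29.9%. Compound 2 `COc1cc(/C=C/C(=O)C2=C(/C=C/c3ccc(O)c(OC)c3)NC(=O)NC2c2ccc(O)cc2)ccc1O` shares its core and gives 33.3% in this assay, which is the higher of the two numbers, though the difference, a number 3.4 percentage points higher from compound 1 to compound 2 (within the scatter), lies within the scatter, so the two values cannot be ranked against each other. Compound 3 `COc1cc(/C=C/C(=O)C2=C(/C=C/c3ccc(O)c(OC)c3)NC(=O)NC2c2ccccc2Cl)ccc1O` has not been measured. It differs from compound 2 in one place: 2-chlorophenyl in place of 4-hydroxyphenyl on a saturated ring carbon. Going by the values given here, the only step measured so far at this saturated ring carbon is the one from compound 1 to compound 2, a number 3.4 percentage points higher from compound 1 to compound 2 (within the scatter), which moved the hydroxyl group on the phenyl ring without any effect beyond the scatter. No measured step exchanges a hydroxyl for chlorine, so the present change has no direct precedent among these compounds. Among the compounds with values here, on the evidence of the single step at this position, a step of a number 3.3 percentage points lower from compound 2 to compound 3 (within the scatter) is expected, staying within the scatter. Compound 3 is therefore estimated to give 30% in this assay, within a range from 15% to 45%.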

Compound 3, a percentage reported as activity, at one concentration (the size of the read-out at that concentration, not a potency): 16.6%
The estimate for compound 3 lay 13.4 percentage points above the measured number; measured number inside the range.
By their numbers in this assay, from the lowest: compound 3; then compounds 1 and 2 (each within the scatter of the next).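

In this assay the group on the saturated ring carbon now proves able to move the number beyond the scatter: the earlier shift of the hydroxyl group around the phenyl ring did not, whereas 2-chlorophenyl in place of 4-hydroxyphenyl gives a number 16.7 percentage points lower from compound 2 to compound 3 (beyond the scatter). The closer comparison, chloro in place of hydroxy on an aromatic carbon, gives a number 13.3 percentage points lower from compound 1 to compound 3 (beyond the scatter), so the drop also appears when the substituent is exchanged without the change from 4-hydroxyphenyl, and among these three compounds only compound 3 stands apart from both others beyond the scatter. No measured evidence is available to explain this drop.

The compounds shown do not separate the loss of the hydroxyl group from the arrival of chlorine, and they leave open how an unsubstituted phenyl, or a phenyl carrying a methoxy group or an amine, would read in this assay. They also leave open whether chlorine elsewhere on the phenyl ring, or a bromine or a methyl group in its place, would give a number like that of compound 3 16.6% or one nearer those of the hydroxyphenyl compounds.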